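Furan Amide in Place of tert-Butylphenyl on the Shared Core

The source may hold more compounds than are shown below. What is called first, only, known or untested is meant among the compounds shown, and "the series" means these compounds.

Of the compounds shown here, three built on one shared core have so far been tested in an ADME assay on Vero cells (Chlorocebus sabaeus) for cytotoxicity, read by resazurin assay, with a stated time of 3 days; on this read-out higher numbers stand for weaker inhibition and lower numbers for stronger inhibition. Compound 1 `CN(C)c1cc2[nH]c(C3CCCCC3)nc2cc1NC(=O)OCc1ccccc1` gives > 100 ug/mL, which is a limit of the assay rather than a number. Compound 2 `CN(C)c1cc2[nH]c(C3CCCCC3)nc2cc1NC(=O)c1ccc(C(C)(C)C)cc1` gives > 100 ug/mL, likewise a limit. Compound 3 `CCN(CC)c1cc2[nH]c(C3CCCCC3)nc2cc1NC(=O)c1ccc(OC(F)(F)F)cc1` gives > 100 ug/mL, again a limit. Compound 2 therefore stands only at a limit, and the two other values are limits as well, so nothing separates it from its neighbours. For the measured compounds named here, the one step that can be traced is a step that the two limits leave unreadable from compound 1 to compound 2; it stays unreadable because both of its values sit at the limit of > 100 ug/mL in this assay, at which 3 of the 3 values shown sit.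

Compound 4 `CN(C)c1cc2[nH]c(C3CCCCC3)nc2cc1NC(=O)c1ccco1` has not yet been measured in this assay. It differs from compound 2 by furan-2-yl in place of 4-(tert-butyl)phenyl on a carbonyl carbon. Going by the values given here, the only measured step touching this carbonyl carbon is the unreadable one from compound 1 to compound 2, so no measured step gives a direction or size for this change. On that basis compound 4 is expected to remain at the limit, and the step that the limit leaves unreadable from compound 2 to compound 4 is estimated to be none beyond the scatter. The estimate for compound 4 is 150 ug/mL, with a range from 60 ug/mL to 400 ug/mL.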

Compound 4, half-maximal inhibitory concentration: > 100 ug/mL
Compound 4: a limit, no number (the forecaster's own chance of this, stated with the estimate: 75%); the middle value lies beyond the limit too.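

Compound 4 also sits at a limit, so the steps from compound 2 and from compound 1 to compound 4 cannot be read, because both ends of each step lie at the same limit: the limit of > 100 ug/mL in this assay, at which 4 of the 4 values shown sit. The compounds shown leave open how furan-2-yl and 4-(tert-butyl)phenyl on a carbonyl carbon compare in this assay beyond that limit.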